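The compounds below may be only part of what the source reports. "The series", "measured", "known", "first", "only" and "open" are said of these compounds alone.

Of the compounds shown here, two have been measured so far. Compound 1 `CO[C@H]1CC[C@H](Nc2cc(NCc3cnccc3C(F)(F)F)ncc2C#N)CC1` reaches only a limit in an assay on isolated protein for inhibition of protein kinase C delta type (Homo sapiens), read by TR-FRET, with a stated time of 2 h (on this read-out lower numbers stand for stronger inhibition and higher numbers for weaker inhibition), where compound 1 gives > 10000 nM. Compound 2 `CC1(C)[C@@H](C(N)=O)C[C@H]1Nc1cc(NCc2cnccc2C(F)(F)F)ncc1C#N` gives 160 nM in this assay, the only number shown. The other value, that of compound 1, is a limit (the limit of > 10000 nM in this assay, at which 1 of the 2 values shown sits). For the measured compounds named here, the single measured step, an at least 62-fold lower number from compound 1 to compound 2 (1.79 log units; beyond the scatter), is large and exchanges one saturated ring for another. Compound 3 `CC1(C)[C@@H](Nc2cc(NCc3cnccc3C(F)(F)F)ncc2C#N)C[C@@H]1C(N)=O` differs from compound 2 as follows: the two compounds have the same atoms and bonds and differ only in configuration as drawn: 1 of 2 stereo elements differ; a stereocentre at a saturated ring carbon is drawn R in compound 2 and S in compound 3. Going by the values given here, no measured step bears on a change of configuration alone, so the size and direction of the expected step cannot be read from the data. Compound 3 is therefore estimated, with wide uncertainty, to give 600 nM in this assay, between 100 nM and 6000 nM. This estimate means an expected step of a 3.8-fold higher number from compound 2 to compound 3 (0.57 log units; beyond the scatter).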

Compound 3, half-maximal inhibitory concentration: > 10000 nM
Compound 3: a limit, no number; the forecaster's own chance of this, stated with the estimate: 15%; at least 16-fold (1.22 log units) between middle value and limit.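

The change at one saturated ring carbon gives an at least 62-fold higher number from compound 2 to compound 3 (1.79 log units; beyond the scatter), so in this assay the configuration at this position decides the result, and the step rests on configuration alone: the fact that compounds 2 and 3 differ only in the configuration as drawn. The 3-carbamoyl-2,2-dimethylcyclobutyl group is therefore not enough by itself, as compound 3 carries it and still reaches only a limit, the same one as compound 1: the limit of > 10000 nM in this assay, at which 2 of the 3 values shown sit. With both compounds at a limit, the step between compound 1 and compound 3 cannot be read.

The compounds shown leave open what happens when the other stereocentre is inverted, alone or together with this one. They also leave open whether a carboxylic acid or an aminomethyl group in place of the carbamoyl group would keep the number of compound 2.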